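Acetoxyalkyl chain branching in the methoxyphenyl enone series

The compounds below may be only part of what the source reports. "The series", "measured", "known", "first", "only" and "open" are said of these compounds alone.

Compound 2 `COc1ccc(C(=O)/C(=C/C2CCCCC2)CCOC(C)=O)cc1` sits at a limit of the assay: in a functional assay on MCF7 cells (Homo sapiens) for inhibition, read by XTT assay, with a stated time of 48 h (on this read-out higher numbers stand for weaker inhibition and lower numbers for stronger inhibition), compound 2 gives > 100000 nM. Compound 1 `COc1ccc(C(=O)/C(=C/C2CCCCC2)COC(C)=O)cc1` gives 24000 nM in this assay, and the step of an at least 4.1-fold higher number from compound 1 to compound 2 (0.61 log units; beyond the scatter) is acetoxymethyl in place of acetoxy. Compound 3 `COc1ccc(C(=O)/C(=C/c2ccccc2Cl)CCOC(C)=O)cc1` also sits at a limit, giving > 100000 nM. The step that the two limits leave unreadable from compound 2 to compound 3 cannot be sized since the limit of > 100000 nM in this assay, at which 2 of the 3 values shown sit, covers two of the three values. Compound 4 `COc1ccc(C(=O)/C(=C/C2CCCCC2)CC(C)OC(C)=O)cc1` differs from compound 2 by methyl in place of hydrogen on a saturated chain carbon bound to an oxygen next to a carbonyl group and a saturated chain carbon. Among the compounds with values here, no measured step bears directly on this change; the only readable step, an at least 4.1-fold higher number from compound 1 to compound 2 (0.61 log units; beyond the scatter), runs toward the limit. No step beyond the scatter is expected, so compound 4 is estimated at 100000 nM (range 30000 nM to 300000 nM). The step of a number no higher from compound 2 to compound 4 (the limit leaves the size open) is expected to be none beyond the scatter.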

Compound 4, half-maximal inhibitory concentration: > 100000 nM
Compound 4: only a limit was reported; the forecaster's own chance of this, stated with the estimate: 70%; the middle value sits exactly at the limit.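

In this assay compound 4 gives > 100000 nM, which is a limit of the assay and not a number. With 1-acetoxyethyl in place of acetoxy on the saturated chain carbon, the series shows an at least 4.1-fold higher number from compound 1 to compound 4 (0.61 log units; beyond the scatter), so the added methyl does not bring the reading back into the measurable range. The step between compound 2 and compound 4 cannot be read, and neither can the step between compound 2 and compound 3: the limit of > 100000 nM in this assay, at which 3 of the 4 values shown sit.

Going by these compounds, whether the methyl changes inhibition at all stays open. Also open, on these data alone, is whether an amine or a carboxylic acid in place of the acetoxy group would give a reading inside the limit.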